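The source may report more compounds than this note shows. Statements on the series, on what has been measured and on what is new or still open speak of the compounds shown alone.

Measured so far in a functional assay on SW-620 cells (Homo sapiens) for antiproliferative activity, read by MTT assay, with a stated time of 72 h; on this read-out higher numbers stand for weaker inhibition and lower numbers for stronger inhibition:
compound 1 `CC(C)(C)c1cn(C[C@H](O)[C@H]2OC(=O)C(OCc3ccccc3)=C2OCc2ccccc2)nn1`, 35800 nM.
compound 2 `COc1ccc(-c2cn(C/C=C3\OC(=O)C(OCc4ccccc4)=C3OCc3ccccc3)nn2)cc1`, > 100000 nM, a limit of the assay.
compound 3 `O=C1O/C(=C\Cn2cc(-c3cc(F)cc(F)c3)nn2)C(OCc2ccccc2)=C1OCc1ccccc1`, > 100000 nM, a limit of the assay.

Within the data shown here, compound 1 holds the only number in this set; the other two values are limits. Two of the three values sit at the limit of > 100000 nM in this assay, at which 2 of the 3 values shown sit. Among the measured compounds shown here, the one single-point step, a step that the two limits leave unreadable from compound 2 to compound 3, runs between two limits and its size cannot be read. For the measured compounds named here, compounds 2 and 3 also share a core that differs from that of compound 1, so no measured step connects them to compound 1 directly.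

Compound 4 `O=C1O[C@H]([C@@H](O)Cn2cc(-c3cccc(O)c3)nn2)C(OCc2ccccc2)=C1OCc1ccccc1` is compound 1 with 3-hydroxyphenyl in place of tert-butyl on an aromatic carbon. Going by the values given here, no measured step bears on this change. The two compounds that carry 4-methoxyphenyl or 3,5-difluorophenyl in that place, compound 2 and compound 3, gave only limits, but they differ from compound 1 elsewhere as well, so they carry no readable weight here. The expectation is a step of a 1.7-fold higher number from compound 1 to compound 4 (0.22 log units; within the scatter) in this assay, toward weaker inhibition if anything, with a real chance that only a limit is returned. Compound 4 is estimated at 60000 nM, in the range 15000 nM to 150000 nM.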

Compound 4, half-maximal inhibitory concentration: > 100000 nM
Compound 4 was reported as a limit; the forecaster's own chance of this, stated with the estimate: 40%; at least 1.6-fold (0.22 log units) between middle value and limit.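

In this assay, among these compounds, the first readable step at this position is an at least 2.7-fold higher number from compound 1 to compound 4 (0.44 log units; beyond the scatter), toward weaker inhibition, with 3-hydroxyphenyl replacing tert-butyl on the aromatic carbon of the core of compound 1. Compound 4 gives > 100000 nM, a limit of the assay. Until now no readable step touched this position, and with this change compound 1 remains the only compound in the set with a number: the limit of > 100000 nM in this assay, at which 3 of the 4 values shown sit.

From the compounds shown here alone, with one replacement on the core of compound 1, it stays open whether the weaker result goes with the aromatic ring itself or with its hydroxyl group, and steps that run between two limits cannot be read. Plain phenyl or methyl on the same aromatic carbon, each compared directly with compound 1, would begin to separate these two readings, and a compound that returns a number in place of a limit would give this step a measured size.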